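This account rests on a few compounds, and the source may have more. Where it says the series, first, only, none or still open, it means among the compounds named here.

Measured so far in a functional assay on SK-OV-3 cells (Homo sapiens) for cytotoxicity, read by sulforhodamine B assay, with a stated time of 48 h; on this read-out lower numbers stand for stronger inhibition and higher numbers for weaker inhibition:

compound 1, `Cc1ccc2nc(NCCCCOc3cc(O)c4c(=O)cc(-c5ccccc5)oc4c3)sc2c1`: 48.4 ug/mL
compound 2, `O=c1cc(-c2ccccc2)oc2cc(OCCCCNc3nc4ccc(Cl)cc4s3)cc(O)c12`: 39.3 ug/mL

In this assay compound 2 holds the lowest of the two numbers, though compound 1 sits within the scatter of it. Compound 3, `O=c1cc(-c2ccccc2)oc2cc(OCCCCNc3nc4ccc(I)cc4s3)cc(O)c12`, differs from compound 2 by iodo in place of chloro on an aromatic carbon. Among the measured compounds shown here, the one measured step, a 1.2-fold lower number from compound 1 to compound 2 (0.09 log units; within the scatter), also a change on an aromatic carbon of the shared core, stayed within the scatter; no step involving iodo at that carbon is available. For compound 3 the expected step of a 1.1-fold lower number from compound 2 to compound 3 (0.03 log units; within the scatter) is accordingly no shift beyond the scatter. Compound 3 is estimated at 37 ug/mL, range 18 ug/mL to 75 ug/mL.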

Compound 3, half-maximal inhibitory concentration: 56.4 ug/mL
Estimate against measurement, compound 3: 1.5-fold (0.18 log units) below; the range from low to high includes it.
By their numbers in this assay, from the lowest: compounds 2, 1 and 3 (each within the scatter of the next).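

On the aromatic carbon of the 6-chloro-1,3-benzothiazol-2-yl group, iodo in place of chloro gives a 1.4-fold higher number from compound 2 to compound 3 (0.16 log units; within the scatter) in this assay and iodo in place of methyl gives a 1.2-fold higher number from compound 1 to compound 3 (0.07 log units; within the scatter) on the same read-out. Methyl, chloro and iodo at this carbon are therefore not told apart by this assay in these three compounds, so the flat picture from the first step now extends to a third group. No measurement is at hand that bears on the reason for this.

From the compounds shown here alone, whether an amine or a carboxylic acid at this carbon would give a step beyond the scatter stays open. So does the effect of a longer chain between the shared core and the amino nitrogen.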